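Inverting One Stereocentre in a Hydroxy-Acid Series

This account rests on a few compounds, and the source may have more. Where it says the series, first, only, none or still open, it means among the compounds named here.

Three hydroxy-acids have so far been tested in an assay on isolated protein for inhibition of ATP-citrate synthase (Homo sapiens); a lower number here means a stronger inhibitor, a higher number a weaker inhibitor. Compound 1 `O=C(O)C[C@](O)(C(=O)O)[C@@H](O)CCCCCCCc1ccc(Cl)cc1Cl` gives 5700 nM in this assay. Compound 2 `O=C(O)C[C@](O)(C(=O)O)[C@@H](O)CCCCCCCCc1ccc(Cl)cc1Cl`, which carries one more chain carbon before the dichlorinated ring, gives 18000 nM; the step of a 3.2-fold higher number from compound 1 to compound 2 (0.50 log units; beyond the scatter) shows that lengthening the chain weakens inhibition. Compound 3 `O=C(O)[C@@H](O)[C@@](O)(C[C@H](O)CCCCCCc1ccc(Cl)cc1Cl)C(=O)O`, built on a different arrangement of the same hydroxyl and carboxyl groups, gives 620 nM and stands lowest of the three numbers, clearly separated from both compound 1 and compound 2.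

Compound 4 `O=C(O)[C@H](O)[C@@](O)(C[C@H](O)CCCCCCc1ccc(Cl)cc1Cl)C(=O)O` is its closest relative: the two compounds have the same atoms and bonds and differ only in configuration as drawn: 1 of 3 stereo elements differ; a stereocentre at a saturated chain carbon is drawn S in compound 3 and R in compound 4. Within the data shown here, the only measured step in this assay concerns chain length between compound 1 and compound 2, and no measured pair differs in configuration alone, so nothing on hand shows how this assay responds to flipping one centre. Experience with stereoisomers of closely packed hydroxyl and carboxyl groups suggests the effect can be substantial in either direction, and a weakening is somewhat more often seen than a gain when the better-performing isomer is the one already measured. Compound 4 is therefore expected at 2500 nM, within a wide range of 400 nM to 20000 nM, an estimated step of a 4.0-fold higher number from compound 3 to compound 4 (0.61 log units; beyond the scatter).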

Compound 4, inhibition constant: 550 nM
Beside the measured number, compound 4's estimate is 4.5-fold (0.66 log units) above it; low and high end bracket the measured number.
By their numbers in this assay, from the lowest: compounds 4 and 3 (each within the scatter of the next); then compound 1; then compound 2.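

In this assay the stereocentre at this saturated chain carbon can be inverted with no readable consequence: the step is a 1.1-fold lower number from compound 3 to compound 4 (0.05 log units; within the scatter) and cannot be told apart from repeat measurements of one compound. Among these compounds, the earlier compounds could not show this, since the only step among them, a 3.2-fold higher number from compound 1 to compound 2 (0.50 log units; beyond the scatter), concerns one more chain carbon and says nothing about configuration. For compounds 3 and 4, this pair isolates the drawn arrangement at one centre as the sole variable, and the result is read as a test of that centre alone because nothing else separates the two structures: the fact that compounds 3 and 4 differ only in the configuration as drawn.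

The compounds shown leave open whether the other two stereo elements of this core are just as undemanding, since a flat result at one centre does not carry over to its neighbours in the same molecule. They also leave open whether this carbon needs its hydroxyl at all, and whether an amine or a simple hydrogen in its place would keep the inhibition, which would show if the lack of response to inversion reflects a group that matters little here.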